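The compounds below may be only part of what the source reports. "The series", "measured", "known", "first", "only" and "open" are said of these compounds alone.

Measured: compound 1 `CC1CC/C(=N\Nc2ccccc2F)c2ncc(C(=O)O)c(=O)n21`, > 1000 umol/kg; compound 2 `COc1ccc(N/N=C2\CCC(C)n3c2ncc(C(=O)O)c3=O)cc1`, 7.6 umol/kg.

In a functional assay on the whole organism for inhibition, with Rattus norvegicus as the target (a higher number here means that more compound is needed for the effect, a lower number that less compound is needed), compound 1 gives only a limit, > 1000 umol/kg; this is the limit of > 1000 umol/kg in this assay, at which 1 of the 2 values shown sits. Among the measured compounds shown here, compound 2 gives 7.6 umol/kg in this assay, the single measured step being an at least 130-fold lower number from compound 1 to compound 2 (2.11 log units; beyond the scatter). Compound 3 `CC(=O)c1ccccc1N/N=C1\CCC(C)n2c1ncc(C(=O)O)c2=O` differs from compound 1 by acetyl in place of fluoro on an aromatic carbon. The measured step concerns a different group at a different place on the same ring, so it bears only loosely on this change. A moderate fall is expected, an at least 10-fold lower number from compound 1 to compound 3 (1.00 log units; beyond the scatter), with wide uncertainty. Compound 3 is estimated at 100 umol/kg, between 10 umol/kg and 1000 umol/kg.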

Compound 3, dose for 50% inhibition: > 1000 umol/kg
Compound 3: a limit, no number (the forecaster's own chance of this, stated with the estimate: 35%); middle value at least 10-fold (1.00 log units) away from the limit.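

Compound 1 and compound 3 are both only limits in this assay, so the step between them cannot be read: the limit of > 1000 umol/kg in this assay, at which 2 of the 3 values shown sit.

From the compounds shown here alone, how acetyl and fluoro compare on the aromatic carbon remains open.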